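Hydroxy for methyl on an unmeasured side chain

A few compounds are considered here, and "the series" means these few. Any claim that something is new, unique, unknown or untested is made for them only; others in the source may bear on it.

In an ADME assay on MDCK cells (Canis lupus familiaris) for permeability, in the apical to basolateral direction (on this read-out lower numbers stand for lower permeability and higher numbers for higher permeability), compound 2 (`CC(C)(C)C(=O)Nc1sc(S(=O)(=O)c2ccc(F)cc2)cc1C(N)=O`) offers no number: its result reads "not determined" (no result reported) and leaves no starting point for comparison. The change from compound 2 to compound 4 (`CC(C)(O)C(=O)Nc1sc(S(=O)(=O)c2ccc(F)cc2)cc1C(N)=O`) is hydroxy in place of methyl on a saturated chain carbon bound to a carbonyl carbon and two saturated chain carbons and amounts to hydroxy in place of methyl on a saturated chain carbon bound to a carbonyl carbon and two saturated chain carbons, turning tert-butyl into 1-hydroxy-1-methylethyl.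

Going by the values given here, only two related compounds have numbers. In this assay compound 1 (`CN(Cc1ccccc1)S(=O)(=O)c1cc(C(N)=O)c(NC(=O)c2ccn[nH]2)s1`) gives 0.65 10^-6 cm/s and compound 3 (`NC(=O)c1cc(S(=O)(=O)N2CCCCC2)sc1NC(=O)c1ccn[nH]1`) gives 0.5 10^-6 cm/s on the same read-out. Among the compounds with values here, the single measured step is a 1.3-fold lower number from compound 1 to compound 3 (0.11 log units; within the scatter) and it concerns the group on the sulfonyl sulfur, not the exchange at hand. Within the data shown here, no measured step covers hydroxy in place of methyl, and compound 2 has no value to step from, so neither a size nor a direction can be expected for this change.

The expectation therefore leans only loosely on compound 1 at 0.65 10^-6 cm/s and compound 3 at 0.5 10^-6 cm/s as a neighbourhood, and both differ from compound 4 in other places too. For compound 4 the estimate is 1 10^-6 cm/s and the expected range runs from 0.3 10^-6 cm/s to 5 10^-6 cm/s on this wide basis.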

Compound 4, apparent permeability: 4 10^-6 cm/s
Compound 4: middle estimate off by 4.0-fold (0.60 log units), on the low side; measured number inside the range.
By their numbers in this assay, from the lowest: compounds 3 and 1 (each within the scatter of the next); then compound 4.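

In this assay compound 2 has no number to set against compound 4, so no step can be read between them. The compounds shown leave open what hydroxy in place of methyl does on this read-out when both partners carry a number. Nothing shown bears on the result for compound 4.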